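The source may hold more compounds than are shown below. What is called first, only, known or untested is meant among the compounds shown, and "the series" means these compounds.

Measured in a functional assay on M21 cells (Homo sapiens) for antiproliferative activity, read by sulforhodamine B assay, with a stated time of 48 h; a higher number here means a weaker inhibitor, a lower number a stronger inhibitor:
Compound 1 `Cc1cccc(OS(=O)(=O)c2ccc(N3CCN(C)C3=O)cc2)c1`: 2300 nM
Compound 2 `CN1CCN(c2ccc(S(=O)(=O)Oc3cccc([N+](=O)[O-])c3)cc2)C1=O`: 23000 nM

Of the two measured compounds, compound 1 stands lowest in this assay at 2300 nM, which makes it the stronger inhibitor of the pair. Compound 3 `Cc1ccc(OS(=O)(=O)c2ccc(N3CCN(C)C3=O)cc2)cc1` has the same atoms as compound 1, joined differently: 4-methylphenyl in place of 3-methylphenyl on an oxygen. Thus 4-methylphenyl takes the place of 3-methylphenyl on an oxygen whose other neighbour is the sulfonyl sulfur. Going by the values given here, only one measured step bears on this, and only indirectly: a 10-fold higher number from compound 1 to compound 2 (1.00 log units; beyond the scatter), with nitro in place of methyl on an aromatic carbon. That step shows the number can shift beyond the scatter when this part of the structure changes, but it exchanges one group for another, whereas compound 3 keeps the same atoms. Among the compounds with values here, no measured step covers a change of this kind, so no clear direction can be argued. The estimate is therefore a 1.1-fold higher number from compound 1 to compound 3 (0.04 log units; within the scatter), with no expected shift beyond the scatter, though the uncertainty is wide. For compound 3 the expected value is 2500 nM, with an estimated range from 700 nM to 9000 nM.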

Compound 3, half-maximal inhibitory concentration: > 100000 nM
Compound 3: no number, only a limit (the forecaster's own chance of this, stated with the estimate: 5%); middle value at least 40-fold (1.60 log units) from the limit.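

In this assay, 4-methylphenyl in place of 3-methylphenyl on the oxygen whose other neighbour is the sulfonyl sulfur gives an at least 43-fold higher number from compound 1 to compound 3 (1.63 log units; beyond the scatter). The earlier step, a 10-fold higher number from compound 1 to compound 2 (1.00 log units; beyond the scatter), exchanged one group for another, whereas this one shows that the same atoms, joined differently, are enough to shift the number beyond the scatter. The value of compound 3 is a limit and not a number: the limit of > 100000 nM in this assay, at which 1 of the 3 values shown sits.

The compounds shown leave open how far compound 3 lies past that limit, and whether an amine or a carboxylic acid in place of the methyl of 4-methylphenyl would fare the same. They also leave open whether an ethyl group in place of the methyl of 3-methylphenyl would keep the number of compound 1.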